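Opening the Ring Amine on the Side Chain of Compound 1

The source may report more compounds than this note shows. Statements on the series, on what has been measured and on what is new or still open speak of the compounds shown alone.

Measured compounds:
compound 1 `CC(C)=CCc1cc(C(=O)Nc2cc3ccc(OCC4CCCN(C)C4)c(C)c3oc2=O)ccc1O`, 1300 nM
compound 2 `CC(C)=CCc1cc(C(=O)Nc2cc3ccc(OCCCN4CCCC4)c(C)c3oc2=O)ccc1O`, 720 nM
compound 3 `CC(C)=CCc1cc(C(=O)Nc2cc3ccc(OCCCNC(C)(C)C)c(C)c3oc2=O)ccc1O`, 660 nM

In a functional assay on SK-BR-3 cells (Homo sapiens) for antiproliferative activity (on this read-out lower numbers stand for stronger inhibition and higher numbers for weaker inhibition), compound 1 gives 1300 nM, the highest of the three numbers recorded, though its two neighbours sit close: a 1.8-fold lower number from compound 1 to compound 2 (0.26 log units; within the scatter), and a 2.0-fold lower number from compound 1 to compound 3 (0.29 log units; within the scatter). Compound 2 and compound 3 are likewise close to each other: a 1.1-fold lower number from compound 2 to compound 3 (0.04 log units; within the scatter).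

Compound 4 `COC(=O)CNCCCOc1ccc2cc(NC(=O)c3ccc(O)c(CC=C(C)C)c3)c(=O)oc2c1C` has not yet been measured. It differs from compound 1 in one place: 2-(((methoxycarbonyl)methyl)amino)ethyl in place of 1-methylpiperidin-3-yl on a saturated chain carbon bound to an oxygen on an aromatic ring. Among the compounds with values here, the nearest precedent is the step from compound 1 to compound 3, where the ring amine was also replaced by an open chain bearing a secondary amine, and that step stayed inside the scatter. The step from compound 1 to compound 2 points the same way and was equally small. Compound 4 is therefore expected to land near compound 1 or slightly under it, a step of a 1.5-fold lower number from compound 1 to compound 4 (0.18 log units; within the scatter), not beyond the scatter. The estimated value of compound 4 is 850 nM, in the range 350 nM to 2000 nM.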

Compound 4, half-maximal inhibitory concentration: 1060 nM
For compound 4 the middle estimate is 1.2-fold (0.10 log units) below the measured one, within the range that was stated.
By their numbers in this assay, from the lowest: compounds 3, 2, 4 and 1 (each within the scatter of the next).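

The ring amine of compound 1 could give way not only to the open chains of compound 2 and compound 3 but also to 2-(((methoxycarbonyl)methyl)amino)ethyl, a chain that adds a double bond and oxygen atoms, without leaving the scatter in this assay (a 1.2-fold lower number from compound 1 to compound 4 (0.09 log units; within the scatter)). At the amine end of the chain, the tert-butyl group and the pyrrolidin-1-yl ring could each be exchanged for a group carrying methoxycarbonyl with the same outcome (a 1.6-fold higher number from compound 3 to compound 4 (0.21 log units; within the scatter); a 1.5-fold higher number from compound 2 to compound 4 (0.17 log units; within the scatter)), so all four compounds now sit within the scatter of one another. Nothing available bears on the reason for this flat response.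

From the compounds shown here alone, it remains open whether a carboxylic acid in place of the methoxycarbonyl group would stay within that scatter. The same question stands for a longer chain between the oxygen and the amine.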